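The source may hold more compounds than are shown below. What is called first, only, known or untested is meant among the compounds shown, and "the series" means these compounds.

Three compounds that share one core were tested in an assay on isolated protein for inhibition of DNA topoisomerase 1 (Homo sapiens), with a stated time of 30 min, tested at 100 uM; a lower number here means a weaker effect, a higher number a stronger effect of the compound at the concentration tested. Compound 1 `Oc1ccc(-c2cc(-c3cccnc3)nc(-c3ccccc3Cl)c2)cc1` gives 0.9% in this assay. Compound 2 `Oc1ccc(-c2cc(-c3cccs3)nc(-c3ccccc3Cl)c2)cc1` gives 2.2%, and compound 3 `Oc1ccc(-c2cc(-c3ccco3)nc(-c3ccccc3Cl)c2)cc1` gives 3.9%. Compound 1 has the lowest of the three numbers, yet the steps of a number 1.3 percentage points higher from compound 1 to compound 2 (within the scatter) and a number 3 percentage points higher from compound 1 to compound 3 (within the scatter) both lie within the scatter, and so does the step of a number 1.7 percentage points higher from compound 2 to compound 3 (within the scatter), so the three compounds cannot be told apart on these data.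

Compound 4 `Oc1ccc(-c2cc(-c3ccc(Cl)cc3)nc(-c3cccnc3)c2)cc1` has not yet been measured in this assay. It differs from compound 1 in one place: 4-chlorophenyl in place of 2-chlorophenyl on an aromatic carbon. Going by the values given here, none of the measured steps touches the chlorophenyl group, so no measured step bears directly on this change; the only guide is that every compound measured so far sits close to zero in this assay. The step from compound 1 to compound 4 in this assay is therefore expected to be a number 2.1 percentage points higher from compound 1 to compound 4 (within the scatter), within the scatter. Compound 4 is estimated at 3% in this assay, in a range from 0% to 12%.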

Compound 4, a percentage reported as inhibition, at one concentration (the size of the read-out at that concentration, not a potency): 18.8%
Compound 4: middle estimate off by 15.8 percentage points, on the low side, and the stated range ends below it.
By their numbers in this assay, from the lowest: compounds 1, 2 and 3 (each within the scatter of the next); then compound 4.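

Among the compounds shown, the chlorophenyl group is the only place where a single change carries the read-out in this assay beyond the scatter, as a number 17.9 percentage points higher from compound 1 to compound 4 (beyond the scatter) shows, whereas the exchanges among pyridin-3-yl, thiophen-2-yl and furan-2-yl all stayed within it. Since 2-chlorophenyl and 4-chlorophenyl have the same atoms and the same counts, the placement of the chlorine on this phenyl ring is all that separates the two compounds. The data on hand offer no measurement that would explain this difference.

From the compounds shown here alone, it remains open whether a methoxy group or an amine in place of the chlorine of the 4-chlorophenyl group would hold this read-out. Also open, going by these compounds, is whether 4-chlorophenyl gives a similar step alongside thiophen-2-yl or furan-2-yl instead of pyridin-3-yl.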